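Swapping the Aryl Group on a Glutamate Receptor Antagonist

The source may report more compounds than this note shows. Statements on the series, on what has been measured and on what is new or still open speak of the compounds shown alone.

Three compounds sharing one core have been examined in an in vitro functional assay on cells for antagonist activity at metabotropic glutamate receptor 1 (Homo sapiens), read by FLIPR and calcium flux; a lower number here means a stronger inhibitor, a higher number a weaker inhibitor. Compound 1 `Cc1nc2c(cnn2-c2ccccc2)c(=O)n1N1CCCCC1` gives 91 nM. Compound 2 `Cc1cccc(-n2ncc3c(=O)n(-c4ccc(Cl)cc4)c(C)nc32)c1` gives 180 nM, a number within the scatter of compound 1 and far from compound 3 `Cc1nc2c(cnn2-c2ccc(S(N)(=O)=O)cc2)c(=O)n1-c1ccc(Cl)cc1`, which gives 1410 nM. Compound 4 `Cc1nc2c(cnn2-c2cncnc2)c(=O)n1-c1ccc(Cl)cc1` has not yet been measured; it differs from compound 2 by pyrimidin-5-yl in place of 3-methylphenyl on an aromatic nitrogen. Among the compounds with values here, no measured pair shows this kind of change directly, so the step can only be judged from what compound 3 shows: carrying a different group on that aromatic nitrogen, compound 3 gives 1410 nM, a weaker result. The step of a 3.3-fold higher number from compound 2 to compound 4 (0.52 log units; beyond the scatter) is expected to lie beyond the scatter, toward a weaker result. The estimate for compound 4 is 600 nM, in the range 200 nM to 2000 nM.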

Compound 4, half-maximal inhibitory concentration: 9800 nM
Compound 4: middle estimate off by 16-fold (1.21 log units), on the low side; measured number above the stated range.
By their numbers in this assay, from the lowest: compounds 1 and 2 (each within the scatter of the next); then compound 3; then compound 4.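

In this assay, this position on the aromatic nitrogen tolerates the change poorly: pyrimidin-5-yl in place of 3-methylphenyl gives a 54-fold higher number from compound 2 to compound 4 (1.74 log units; beyond the scatter). This swap brings in two ring nitrogens and two hydrogen-bond acceptors, and compound 4 at 9800 nM ends up weaker even than compound 3 at 1410 nM. No measurement at hand accounts for the size of this loss.

The compounds shown leave open whether a pyridin-3-yl group, with a single ring nitrogen, would stay close to compound 2 or fall toward compound 4.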